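Removing a tert-butyl group on a thiazole amide series

The source may report more compounds than this note shows. Statements on the series, on what has been measured and on what is new or still open speak of the compounds shown alone.

Compound 2 `CN1CCN(c2ccc(Nc3nc(-c4cccc(NC(=O)c5ccc(C(C)(C)C)cc5)c4)sc3C(N)=O)cc2)CC1` is one of two measured compounds here, with compound 1 `CN1CCN(c2ccc(Nc3nc(-c4cccc(NC(=O)c5ccccc5)c4)sc3C(=O)O)cc2)CC1` as its only comparator. In a functional assay on Raji cells (Homo sapiens) for antiproliferative activity, read by CCK-8 assay, with a stated time of 72 h, tested at 40 uM (on this read-out lower numbers stand for less inhibition and higher numbers for more inhibition at the one concentration tested (going by the name of the read-out)), compound 2 gives 12.1%, and compound 1 gives 11.9%; the two numbers lie within the scatter of each other, so compound 2 stands alongside compound 1 rather than apart from it. Compound 3 `CN1CCN(c2ccc(Nc3nc(-c4cccc(NC(=O)c5ccccc5)c4)sc3C(N)=O)cc2)CC1` is not yet measured. It differs from compound 2 by hydrogen in place of tert-butyl on an aromatic carbon. Among the compounds with values here, with no measured step to lean on, the change is expected to bring none beyond the scatter, a step of a number 0.1 percentage points lower from compound 2 to compound 3 (within the scatter). Compound 3 is therefore estimated at 12%, in the range 2% to 25%.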

Compound 3, a percentage reported as inhibition, at one concentration (the size of the read-out at that concentration, not a potency): 91.3%
The estimate for compound 3 lay 79.3 percentage points below the measured number; the whole stated range lies below it.
By their numbers in this assay, from the lowest: compounds 1 and 2 (each within the scatter of the next); then compound 3.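

Taking the tert-butyl group off the benzoyl group, with the shared core otherwise unchanged, gives in this assay a number 79.2 percentage points higher from compound 2 to compound 3 (beyond the scatter), so this aromatic carbon carries much of the read-out, which the earlier pair could not show. The carbonyl carbon counts as well: amino in place of hydroxy gives a number 79.4 percentage points higher from compound 1 to compound 3 (beyond the scatter), so either change alone separates compound 3 from the low numbers. Nothing available explains either step. The compounds shown leave open whether a methyl or methoxy group on that aromatic carbon would keep the number of compound 3. They also leave open how a methylamino group on the carbonyl carbon would read.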